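Ethyl, tert-Butyl and Cyclobutyl on the Ring Nitrogen

The source may report more compounds than this note shows. Statements on the series, on what has been measured and on what is new or still open speak of the compounds shown alone.

Compound 1 `CC(C)(C)n1c(-c2cccnc2)nc2ccc(F)cc21`: > 5000 nM
Compound 2 `CCn1c(-c2cccnc2)nc2ccc(F)cc21`: 35 nM

Of the compounds shown here, two have been measured in an assay on V79 cells for inhibition of cytochrome P450 11B2, mitochondrial (Homo sapiens), read by HTRF, with a stated time of 1 h; a higher number here means a weaker inhibitor, a lower number a stronger inhibitor. For compound 1 the value of > 5000 nM is a limit of the assay and not a number (the limit of > 5000 nM in this assay, at which 1 of the 2 values shown sits). Compound 2 gives 35 nM in this assay, the only number shown, so it stands alone as the compound with a measured value. The step of an at least 140-fold lower number from compound 1 to compound 2 (2.15 log units; beyond the scatter) is large. Compound 3 `Fc1ccc2nc(-c3cccnc3)n(C3CCC3)c2c1` differs from compound 2 by cyclobutyl in place of ethyl on an aromatic nitrogen. Among the measured compounds shown here, the one measured step bearing on this change is the exchange of tert-butyl for ethyl on the same ring nitrogen, which was large; cyclobutyl now brings a four-membered ring of carbon where the ethyl chain was. The account therefore expects a higher number for compound 3 than for compound 2, a step of a 4.3-fold higher number from compound 2 to compound 3 (0.63 log units; beyond the scatter) in this assay, smaller than the measured step. The estimate for compound 3 is 150 nM, within 40 nM to 900 nM.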

Compound 3, half-maximal inhibitory concentration: > 5000 nM
Compound 3: only a limit was reported; the forecaster's own chance of this, stated with the estimate: 10%; middle value at least 33-fold (1.52 log units) from the limit.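

In this assay, the change to cyclobutyl gives an at least 140-fold higher number from compound 2 to compound 3 (2.15 log units; beyond the scatter), so at this aromatic nitrogen the loss of a measured value is no longer tied to tert-butyl alone. Compound 3 gives > 5000 nM, which is a limit of the assay and not a number. Of the three groups shown on this nitrogen, only ethyl gives a measured value, and the other two sit at one limit: the limit of > 5000 nM in this assay, at which 2 of the 3 values shown sit.

On these data alone, the step from compound 1 to compound 3 cannot be read, so the order of tert-butyl and cyclobutyl stays open. Also open, as far as these compounds go, is whether a methyl, a propyl chain or a cyclopropyl on the same nitrogen would keep a measured value or reach the same limit.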